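Swapping a phenoxy for a pyridinecarbonylamino group

The source may report more compounds than this note shows. Statements on the series, on what has been measured and on what is new or still open speak of the compounds shown alone.

Compound 1 `Fc1ccc2c(c1CNc1ncc(Oc3ccccc3)c3nncn13)CCO2`: 8000 nM
Compound 2 `CN(C)Cc1ccc2c(c1)CN(c1cnc(NCc3c(F)ccc4c3CCO4)n3cnnc13)C2=O`: 12000 nM

Of the compounds shown here, two have been measured in a physicochemical assay for solubility, read by LC-MS, in phosphate buffer, with a stated time of 24 h, at pH 7.4; a lower number here means a less soluble compound, a higher number a more soluble compound. Compound 1 gives 8000 nM in this assay, the lowest of the two numbers, while compound 2 gives 12000 nM; the two values lie within the scatter of each other, so no order between them can be read.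

Compound 3 `O=C(Nc1cnc(NCc2c(F)ccc3c2CCO3)n2cnnc12)c1cccnc1` has not yet been measured. It differs from compound 1 in one place: ((pyridin-3-yl)carbonyl)amino in place of phenoxy on an aromatic carbon

Among the compounds with values here, no step between measured compounds is available to anchor this change, and the two measured values are close to each other. The step from compound 1 to compound 3 in this assay is expected to be modest and upward, a 1.9-fold higher number from compound 1 to compound 3 (0.27 log units; within the scatter), a rise that may reach just beyond the usual scatter. For compound 3 the estimate in this assay is 15000 nM, with a plausible range from 4000 nM to 50000 nM. The measurement will tell whether this expectation holds.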

Compound 3, solubility: 12000 nM
Estimate against measurement, compound 3: 1.3-fold (0.10 log units) above, and the stated range covers the measured number.
By their numbers in this assay, from the lowest: compounds 1, 2 and 3 (each within the scatter of the next).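

In this assay, within the data shown here, putting ((pyridin-3-yl)carbonyl)amino in place of phenoxy gives a 1.5-fold higher number from compound 1 to compound 3 (0.18 log units; within the scatter) and so supplies the first reading of a single change at this aromatic carbon, which the values of the two earlier compounds, differing from each other in more than one place, could not give. The exchange is not a small one on paper: the entering group has 9 heavy atoms against 7 for phenoxy, 1 hydrogen-bond donor against 0, and an aromatic ring with 1 hetero atom in place of one of carbon only, yet the two numbers cannot be told apart in this read-out. Nothing measured here gives a reason for this result.

The compounds shown do not separate the parts of the entering group, so the pyridine nitrogen, the carbonyl and the amide hydrogen cannot be weighed one against another. On these data alone, whether this aromatic carbon stays equally undemanding with a carboxylic acid, a simple aliphatic amine or a longer chain ending in a morpholine also remains open.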